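A few compounds are considered here, and "the series" means these few. Any claim that something is new, unique, unknown or untested is made for them only; others in the source may bear on it.

Working notes on the series in a functional assay on MDA-MB-231 cells (Homo sapiens) for cytotoxicity, read by MTT assay, with a stated time of 72 h; a higher number here means a weaker inhibitor, a lower number a stronger inhibitor. Compound 1 `O=C1c2c[n+]([O-])c3ccccc3c2C(=O)c2c1c1ccccc1n2Cc1cn([C@H]2O[C@H](CO)[C@@H](O)[C@H]2O)nn1` gives 1700 nM. Compound 2 `O=C1c2c[n+]([O-])c3ccccc3c2C(=O)c2c1c1ccccc1n2CCN1CCCC1` gives 630 nM. The gap between compound 1 and compound 2 lies beyond the scatter. Compound 3 `CCCCN1CCN(CCCCn2c3c(c4ccccc42)C(=O)c2c[n+]([O-])c4ccccc4c2C3=O)CC1` gives 900 nM. The gap between compound 1 and compound 3 lies within the scatter.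

The next compound is compound 4 `CC1(C)O[C@@H](CO)[C@H](Cn2cc(Cn3c4c(c5ccccc53)C(=O)c3c[n+]([O-])c5ccccc5c3C4=O)nn2)O1`, which differs from compound 1 as follows: (5-(hydroxymethyl)-2,2-dimethyl-1,3-dioxolan-4-yl)methyl in place of 3,4-dihydroxy-5-(hydroxymethyl)oxolan-2-yl on an aromatic nitrogen. The shared core is unchanged.

For the measured compounds named here, the only measured step is a 1.4-fold higher number from compound 2 to compound 3 (0.15 log units; within the scatter). It lies within the scatter, even though a large group enters, but it concerns a different side chain and bears on this change only indirectly. Going by the values given here, no measured pair varies the group on the aromatic nitrogen of the five-membered aromatic ring with 3 nitrogen.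

No step beyond the scatter is therefore expected in this assay, with a slight lean towards a lower number, given the span from compound 2 at 630 nM to compound 3 at 900 nM. The estimated value for compound 4 is 1100 nM, with an expected range of 500 nM to 2400 nM. This corresponds to an expected 1.5-fold lower number from compound 1 to compound 4 (0.19 log units; within the scatter).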

Compound 4, half-maximal inhibitory concentration: 680 nM
Estimate against measurement, compound 4: 1.6-fold (0.21 log units) above, within the range that was stated.
By their numbers in this assay, from the lowest: compounds 2, 4, 3 and 1 (each within the scatter of the next, the first and the last beyond it).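

In this assay the group on the aromatic nitrogen of the five-membered aromatic ring with 3 nitrogen is shown for the first time to affect the number: (5-(hydroxymethyl)-2,2-dimethyl-1,3-dioxolan-4-yl)methyl in place of 3,4-dihydroxy-5-(hydroxymethyl)oxolan-2-yl gives a step beyond the scatter, though a modest one (a 2.5-fold lower number from compound 1 to compound 4 (0.40 log units; beyond the scatter)). The exchange alters the ring, the hydrogen-bond donors and acceptors and the defined stereocentres together, so this single step cannot separate their contributions. No measurement at hand accounts for the step.

Which of these differences carries the step remains open. Also open, on these data alone, is how an amine, a carboxylic acid or a longer chain on this aromatic nitrogen would read in this assay against the two sugar-derived groups.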